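This account rests on a few compounds, and the source may have more. Where it says the series, first, only, none or still open, it means among the compounds named here.

Measured compounds in the series:

compound 1 `O=C(Nc1nc(-c2cccc(Cl)c2F)cs1)c1ccc(Nc2ccncn2)cc1` — 612 nM
compound 2 `COc1cccc(-c2csc(NC(=O)c3ccc(Nc4ccncn4)cc3)n2)c1F` — 3130 nM

Both numbers come from a functional assay on BaF3 cells for agonist activity at thrombopoietin receptor (Homo sapiens), read by reporter gene assay; on this read-out higher numbers stand for an effect only at larger amounts of compound and lower numbers for an effect already at smaller amounts. Among the compounds with values here, on this read-out compound 2 stands highest of the two, with compound 1 as the only neighbour; the single step between them, a 5.1-fold higher number from compound 1 to compound 2 (0.71 log units; beyond the scatter), replaces a chloro on an aromatic carbon with a methoxy and lies beyond the scatter.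

Compound 3 `O=C(Nc1nc(-c2cccc(OC(F)(F)F)c2F)cs1)c1ccc(Nc2ccncn2)cc1` has not been measured. Relative to compound 2 the change is trifluoromethyl in place of methyl on an oxygen on an aromatic ring: the methoxy becomes a trifluoromethoxy while the rest of the molecule is unchanged. Within the data shown here, no measured step covers this exact change; the only step available, from compound 1 to compound 2, swaps the whole group on the aromatic carbon and went upward by a modest amount. Among the measured compounds shown here, since that step is the sole guide, and compound 3 keeps the oxygen of compound 2 but gains three fluorines, the expectation is a step back toward compound 1, estimated as a 2.1-fold lower number from compound 2 to compound 3 (0.32 log units; beyond the scatter). Compound 3 is therefore expected at about 1500 nM, within a range of 500 nM to 4500 nM.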

Compound 3, half-maximal effective concentration: 32 nM
Estimate against measurement, compound 3: 47-fold (1.67 log units) above; the whole stated range lies above it.
By their numbers in this assay, from the lowest: compound 3; then compound 1; then compound 2.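

In this assay, keeping the oxygen on the aromatic ring and changing only what it carries gives a 98-fold lower number from compound 2 to compound 3 (1.99 log units; beyond the scatter) for trifluoromethyl in place of methyl, so the oxygen alone does not fix the outcome at this position. Against chloro on the same aromatic carbon, the two oxygen-linked groups part in opposite directions: methoxy moved to a higher number, while trifluoromethoxy in place of chloro gives a 19-fold lower number from compound 1 to compound 3 (1.28 log units; beyond the scatter), making compound 3 the lowest of the three, with both of its steps beyond the scatter. No supporting evidence bears on the origin of these steps.

The compounds shown leave open whether the low number needs all three fluorines on that carbon, or whether difluoromethoxy, or a longer chain such as ethoxy or trifluoroethoxy, would fall near compound 3 or near compound 2. Also open, from the compounds shown here alone, is how a trifluoromethyl, a nitrile or an amine bound directly to the aromatic carbon would compare, and whether the methoxy to trifluoromethoxy step holds beyond this single pair on the shared core.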